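Swapping 4-nitrophenyl for benzyl on a nitrogen

The source may hold more compounds than are shown below. What is called first, only, known or untested is meant among the compounds shown, and "the series" means these compounds.

Of the compounds shown here, three sharing one core have been tested. Compound 1 `COc1cc(C[C@H]2C(=O)OC[C@@H]2Cc2ccc(OC)c(OC)c2)ccc1NC(=O)c1ccccc1` gives > 50000 nM in a functional assay on A549 cells (Homo sapiens) for cytotoxicity, read by MTT assay, with a stated time of 4 days (a lower number here means a stronger inhibitor, a higher number a weaker inhibitor), which is a limit of the assay and not a number. Compound 2 `COc1ccc(Nc2ccc(C[C@H]3C(=O)OC[C@@H]3Cc3ccc(OC)c(OC)c3)cc2OC)cc1` gives > 50000 nM, again only a limit. For the measured compounds named here, compound 3 `COc1cc(C[C@H]2C(=O)OC[C@@H]2Cc2ccc(OC)c(OC)c2)ccc1Nc1ccc([N+](=O)[O-])cc1` gives 22100 nM, the only true number among the three. The measured steps show an at least 2.2-fold lower number from compound 1 to compound 3 (0.35 log units; beyond the scatter) and an at least 2.2-fold lower number from compound 2 to compound 3 (0.35 log units; beyond the scatter), whereas the remaining one is a step that the two limits leave unreadable from compound 1 to compound 2. Going by these compounds, the full size of these steps stays open because of the limit of > 50000 nM in this assay, at which 2 of the 3 values shown sit.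

Compound 4 `COc1cc(C[C@H]2C(=O)OC[C@@H]2Cc2ccc(OC)c(OC)c2)ccc1NCc1ccccc1` differs from compound 3 by one change, benzyl in place of 4-nitrophenyl on a nitrogen on an aromatic ring. Going by the values given here, no measured step makes this exact exchange. The closest guides are the two steps into compound 3, since compound 4 also lacks the nitro group, as compound 1 and compound 2 do. Those steps, an at least 2.2-fold lower number from compound 1 to compound 3 (0.35 log units; beyond the scatter) and an at least 2.2-fold lower number from compound 2 to compound 3 (0.35 log units; beyond the scatter), point towards a modest rise in this assay on leaving 4-nitrophenyl. The expected change is a 1.8-fold higher number from compound 3 to compound 4 (0.26 log units; within the scatter). For compound 4 the estimate is 40000 nM, with an expected range from 15000 nM to 100000 nM, and a report of only a limit would be no surprise.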

Compound 4, half-maximal inhibitory concentration: > 50000 nM
Compound 4: no number, only a limit; the forecaster's own chance of this, stated with the estimate: 60%; middle value at least 1.2-fold (0.09 log units) away from the limit.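

Compound 4 in this assay gives > 50000 nM, which is a limit of the assay and not a number. For the compounds shown here, at this nitrogen on an aromatic ring, the exchange gives an at least 2.2-fold higher number from compound 3 to compound 4 (0.35 log units; beyond the scatter), so benzyl joins benzoyl and 4-methoxyphenyl at the limit, and 4-nitrophenyl remains the only one of the four groups with a true number. The steps into compound 4 from compound 1 and from compound 2 cannot be read, and the order of these three compounds stays unknown: the limit of > 50000 nM in this assay, at which 3 of the 4 values shown sit.

The compounds shown leave open whether this true number depends on the nitro group itself or whether another group in its place on the phenyl ring, such as a nitrile, a carboxylic acid or an amine, would also give one. They also do not tell whether 4-nitrobenzyl on the same nitrogen would bring the value back from the limit seen with benzyl, or whether the direct link between the nitrogen and the nitro-bearing ring matters as well.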